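Alkoxymethylamino analogues on a shared core: cytotoxicity notes

The compounds below may be only part of what the source reports. "The series", "measured", "known", "first", "only" and "open" are said of these compounds alone.

Measured so far:
compound 1 `[O-][n+]1nc(NCOC2CCCCC2)[n+]([O-])c2ccccc21` — 5180 nM
compound 2 `COCNc1n[n+]([O-])c2ccccc2[n+]1[O-]` — 7450 nM

In a functional assay on A549 cells (Homo sapiens) for cytotoxicity, read by MTT assay, with a stated time of 72 h (a lower number here means a stronger inhibitor, a higher number a weaker inhibitor), compound 2 gives 7450 nM, the highest of the two numbers; its nearest neighbour is compound 1, and the two lie within the scatter. Among the compounds with values here, the only measured step, a 1.4-fold higher number from compound 1 to compound 2 (0.16 log units; within the scatter), changes the group on the oxygen and stays within the scatter. Compound 3 `CCCCCOCNc1n[n+]([O-])c2ccccc2[n+]1[O-]` differs from compound 2 by butyl in place of hydrogen on a saturated chain carbon bound to an oxygen on a saturated carbon. That step also varies the chain on the oxygen side, so no shift beyond the scatter is expected, and the estimated step is a 1.2-fold lower number from compound 2 to compound 3 (0.09 log units; within the scatter). Compound 3 is therefore expected at 6000 nM, ranging from 3000 nM to 12000 nM.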

Compound 3, half-maximal inhibitory concentration: 6460 nM
For compound 3 the middle estimate is 1.1-fold (0.03 log units) below the measured one, within the range that was stated.
By their numbers in this assay, from the lowest: compounds 1, 3 and 2 (each within the scatter of the next).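

In this assay, going from methoxy to pentyloxy gives a 1.2-fold lower number from compound 2 to compound 3 (0.06 log units; within the scatter) and so adds butyl at this place with no shift beyond the scatter. Pentyl in place of cyclohexyl on the same oxygen gives a 1.2-fold higher number from compound 1 to compound 3 (0.10 log units; within the scatter) and shows that an open chain and a ring read alike here, with methyl, pentyl and cyclohexyl all within the scatter of one another. No supporting data bear on this flat result.

From the compounds shown here alone, whether a chain longer than pentyl, or an amine or carboxylic acid at the chain end, would move the number beyond the scatter remains open. So does the effect of any change on the shared core.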